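A Bromo Group on the Core of Compound 1

This account rests on a few compounds, and the source may have more. Where it says the series, first, only, none or still open, it means among the compounds named here.

Compound 1 `CN1C(=O)C2(C(C#N)=C(N)Oc3cc4oc(-c5ccccc5)cc(=O)c4c(O)c32)c2ccccc21` gives > 50000 nM
Compound 2 `Cc1ccc2c(c1)C1(C(=O)N2C)C(C#N)=C(N)Oc2cc3oc(-c4ccccc4)cc(=O)c3c(O)c21` gives 5870 nM

In a functional assay on K562 cells (Homo sapiens) for antiproliferative activity, read by MTT assay, with a stated time of 48 h (on this read-out lower numbers stand for stronger inhibition and higher numbers for weaker inhibition), compound 1 gives > 50000 nM as a limit and not a number. Compound 1 stands at the limit of > 50000 nM in this assay, at which 1 of the 2 values shown sits, and no exact number is known for it. Compound 3 `CN1C(=O)C2(C(C#N)=C(N)Oc3cc4oc(-c5ccccc5)cc(=O)c4c(O)c32)c2cc(Br)ccc21` differs from compound 1 by bromo in place of hydrogen on an aromatic carbon and nothing else. Among the measured compounds shown here, the only measured step bearing on this is an at least 8.5-fold lower number from compound 1 to compound 2 (0.93 log units; beyond the scatter) with methyl in place of hydrogen on an aromatic carbon, so a lower number of similar size, beyond the scatter, is expected in this assay for the bromo change. The expected step is an at least 10-fold lower number from compound 1 to compound 3 (1.00 log units; beyond the scatter) in this estimate. Compound 3 is estimated at 5000 nM with an expected range of 1200 nM to 25000 nM in the same read-out.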

Compound 3, half-maximal inhibitory concentration: 4100 nM
The estimate for compound 3 lay 1.2-fold (0.09 log units) above the measured number, within the range that was stated.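

In this assay bromo on this aromatic carbon gives an at least 12-fold lower number from compound 1 to compound 3 (1.08 log units; beyond the scatter) and so shows that the lower number holds for two different groups here, not for methyl alone. Between bromo and methyl there is only a 1.4-fold lower number from compound 2 to compound 3 (0.16 log units; within the scatter) and the two groups cannot be told apart at this position. Compound 1 stands at a limit and not a number, so the size of its step is only a bound: the limit of > 50000 nM in this assay, at which 1 of the 3 values shown sits.

On these data alone, what an amine or a carboxylic acid would give on this same carbon remains open. So does whether bromo or methyl would give a similar step on another carbon of that ring.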